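This account rests on a few compounds, and the source may have more. Where it says the series, first, only, none or still open, it means among the compounds named here.

Compound 1, with the structure `Cc1nn(C)c(Oc2ccccc2)c1/C=N/OCc1ccc(C(F)(F)F)cc1`, is the reference point here. Among the compounds with values here, in a functional assay on MCF7 cells (Homo sapiens) for antiproliferative activity, tested at 1 uM (a lower number here means less inhibition, a higher number more inhibition at the concentration tested (going by the name of the read-out)), compound 1 gives 30.5%, the higher of the two numbers measured so far. Within the data shown here, its only measured neighbour is compound 2, structure `Cc1nn(C)c(Oc2ccc(Cl)cc2)c1/C=N/OCc1ccc(C(F)(F)F)cc1`, which in this assay gives 16.4%; the change that separates them is a number 14.1 percentage points lower from compound 1 to compound 2 (beyond the scatter).

The compound still to be measured is compound 3, structure `Cc1nn(C)c(Oc2ccccc2)c1/C=N/OCc1ccc([N+](=O)[O-])cc1`. Compared with compound 1 it differs in one place: nitro in place of trifluoromethyl on an aromatic carbon.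

Among the measured compounds shown here, no measured step touches this part of the molecule. For the measured compounds named here, the single step on record, from compound 1 to compound 2, alters a different ring, so it shows only that a small change elsewhere can move the number by a modest amount, and gives no direction for swapping one group for another on this ring. Going by the values given here, without a bearing step, the expectation for compound 3 in this assay is a change no larger than the scatter, leaning slightly downward as the one known step did, estimated as a number 3.5 percentage points lower from compound 1 to compound 3 (within the scatter). Compound 3 is therefore expected to give about 27%, in a range from 10% to 45%.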

Compound 3, a percentage reported as inhibition, at one concentration (the size of the read-out at that concentration, not a potency): 24%
The estimate for compound 3 lay 3 percentage points above the measured number; the measured number falls inside the stated range.
By their numbers in this assay, from the lowest: compounds 2, 3 and 1 (each within the scatter of the next, the first and the last beyond it).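

In this assay, within the data shown here, replacing trifluoromethyl with nitro on the aromatic carbon para to a large group gives a number 6.5 percentage points lower from compound 1 to compound 3 (within the scatter), and this is the first reading for any change at this position. Trifluoromethyl and nitro therefore cannot be told apart here, although this single pair at a single concentration does not show that the position is indifferent to other groups, and it says nothing about potency. No measured property of these compounds bears on this result, so what lies behind it remains unknown.

The compounds shown leave open whether a quite different group at this position, such as an amine, a carboxylic acid or a longer chain, would move the number by more than the scatter. They also leave open whether the chloro step, a number 14.1 percentage points lower from compound 1 to compound 2 (beyond the scatter), would look the same with nitro on the other ring in place of trifluoromethyl.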